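Pyridine amide variation on the shared core

This account rests on a few compounds, and the source may have more. Where it says the series, first, only, none or still open, it means among the compounds named here.

Compound 3 `Cc1ccc(C(=O)Nc2cc(-c3ccccc3)nn2-c2ccccc2)cn1` stands second highest of the three numbers in a functional assay on cells for positive allosteric modulation of metabotropic glutamate receptor 5 (Rattus norvegicus), read by calcium flux (on this read-out lower numbers stand for an effect already at smaller amounts and higher numbers for an effect only at larger amounts of compound), giving 280 nM; compound 2 `O=C(Nc1cc(-c2ccccc2)nn1-c1ccccc1)c1ccc(Cl)c(Cl)c1` gives 13 nM and compound 1 `COc1cc(OC)cc(C(=O)Nc2cc(-c3ccccc3)nn2-c2ccccc2)c1` gives 2040 nM. Compound 4 `O=C(Nc1cc(-c2ccccc2)nn1-c1ccccc1)c1ccncc1` carries pyridin-4-yl in place of 6-methylpyridin-3-yl on a carbonyl carbon. Among the measured compounds shown here, every measured step so far changes the group on the carbonyl carbon: a 160-fold lower number from compound 1 to compound 2 (2.20 log units; beyond the scatter), a 7.3-fold lower number from compound 1 to compound 3 (0.86 log units; beyond the scatter) and a 22-fold higher number from compound 2 to compound 3 (1.33 log units; beyond the scatter). For the measured compounds named here, they show that this position moves the number widely, yet none of them exchanges one pyridinyl for another, so no direct precedent for the present change exists. For compound 4 the expected step is a 1.8-fold higher number from compound 3 to compound 4 (0.25 log units; within the scatter), modest and uncertain in direction. Compound 4 is estimated at 500 nM, with a range from 150 nM to 2000 nM.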

Compound 4, half-maximal effective concentration: 2500 nM
Compound 4: middle estimate off by 5.0-fold (0.70 log units), on the low side; measured number outside the range, above it.
By their numbers in this assay, from the lowest: compound 2; then compound 3; then compounds 1 and 4 (each within the scatter of the next).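

Among the compounds shown here, the first exchange of one pyridinyl for another on the carbonyl carbon is far from neutral in this assay, with pyridin-4-yl in place of 6-methylpyridin-3-yl giving an 8.9-fold higher number from compound 3 to compound 4 (0.95 log units; beyond the scatter). Set against the 3,4-dichlorophenyl group, pyridin-4-yl gives a 190-fold higher number from compound 2 to compound 4 (2.28 log units; beyond the scatter), while against the 3,5-dimethoxyphenyl group it gives a 1.2-fold higher number from compound 1 to compound 4 (0.09 log units; within the scatter). No measurement on hand accounts for the step between the two pyridinyl groups.

The methyl group and the place of the ring nitrogen change together in this step, so their shares remain unseparated. Also open, on these data alone, is how an amine or a carboxylic acid on the pyridinyl group would read.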